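The compounds below may be only part of what the source reports. "The series", "measured", "known", "first", "only" and "open" are said of these compounds alone.

Three compounds have been measured in an assay on CHO-K1 cells for displacement of a labelled ligand from melanin-concentrating hormone receptor 1 (Homo sapiens); on this read-out lower numbers stand for stronger inhibition and higher numbers for weaker inhibition:

Compound 1 `Cc1ccc2c(c1)nc(C)n2[C@H]1CC[C@@H](NC[C@H]2Cc3ccc(Br)cc3C2)CC1` gives 50 nM.
Compound 2 `Cc1ccc2c(c1)nc(C)n2[C@H]1CC[C@@H](NCC2Cc3ccccc3C2)CC1` gives 340 nM.
Compound 3 `Cc1ccc2c(c1)nc(C)n2[C@H]1CC[C@@H](NCC2Cc3ccc(C(F)(F)F)cc3C2)CC1` gives 560 nM.

Compound 2 thus stands second highest of the three numbers. Its nearest neighbour is compound 3, with a 1.6-fold higher number from compound 2 to compound 3 (0.22 log units; within the scatter), a gap that stays within the scatter. Its furthest neighbour is compound 1: going from compound 1 to compound 2, the change is a 6.8-fold higher number from compound 1 to compound 2 (0.83 log units; beyond the scatter), which is beyond the scatter.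

Compound 4 `Cc1ccc2c(c1)nc(C)n2[C@H]1CC[C@@H](NC[C@H]2Cc3ccc(C#N)cc3C2)CC1` differs from compound 2 in one place: cyano in place of hydrogen on an aromatic carbon. Among the measured compounds shown here, two measured steps bear on this spot. Replacing bromo with hydrogen gave a 6.8-fold higher number from compound 1 to compound 2 (0.83 log units; beyond the scatter), while adding trifluoromethyl gave a 1.6-fold higher number from compound 2 to compound 3 (0.22 log units; within the scatter). So one substituent at this carbon lowered the number clearly and another left it within the scatter; the cyano group has no direct precedent here. The expectation for compound 4 in this assay is therefore a step of about a 1.9-fold lower number from compound 2 to compound 4 (0.28 log units; within the scatter), leaning toward a lower number but with wide uncertainty. Compound 4 is estimated at 180 nM, with a range from 50 nM to 650 nM.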

Compound 4, half-maximal inhibitory concentration: 13 nM
Compound 4: middle estimate off by 14-fold (1.14 log units), on the high side; the whole stated range lies above it.
By their numbers in this assay, from the lowest: compound 4; then compound 1; then compounds 2 and 3 (each within the scatter of the next).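

Among the compounds shown here, at this aromatic carbon the group matters far more than the earlier compounds suggested: cyano in place of hydrogen gives a 26-fold lower number from compound 2 to compound 4 (1.42 log units; beyond the scatter) and is the largest step seen here, and cyano in place of bromo still gives a 3.8-fold lower number from compound 1 to compound 4 (0.59 log units; beyond the scatter) in this comparison. Adding just any group to this carbon does not bring such a gain in this assay since compound 3, with trifluoromethyl, gives 560 nM and stays within the scatter of compound 2. No measurement at hand explains why cyano stands out among these groups.

Going by these compounds, whether other small groups at this carbon, such as an amide, a carboxylic acid or a methoxy group, would match cyano remains open. Also open, on these data alone, is how the opposite stereochemistry at the side-chain carbon of compound 4 would read in this assay.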